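Cytotoxicity of a benzylamine series in canine kidney cells

This account rests on a few compounds, and the source may have more. Where it says the series, first, only, none or still open, it means among the compounds named here.

Compound 1 `Cc1ccc2[nH]c(=O)c(CN(Cc3ccc(O)cc3)Cc3ccc(C(C)(C)C)cc3)cc2c1` and compound 2 `Cc1ccc2[nH]c(=O)c(CN(Cc3ccc(SC(F)F)cc3)Cc3ccc(C(C)(C)C)cc3)cc2c1` share one core and differ only in the group on one benzyl ring. In a toxicity assay on MDCK cells (Canis lupus familiaris) for cytotoxicity, read by crystal violet staining, with a stated time of 48 h (a lower number here means that less compound is tolerated, a higher number that more compound is tolerated), compound 1 gives 4900 nM. For compound 2 the result is a limit of the assay rather than a number, > 5000 nM. The step of an at least 1.0-fold higher number from compound 1 to compound 2 (0.00 log units; that floor lies within the scatter) therefore tells little, since the limit of > 5000 nM in this assay, at which 1 of the 2 values shown sits, caps what can be seen. Compound 3 `Cc1ccc2[nH]c(=O)c(CN(Cc3ccc(C(C)(C)C)cc3)C(C)c3ccc(N(C)C)c(Cl)c3)cc2c1` carries the change (1-(3-chloro-4-(dimethylamino)phenyl)ethyl in place of 4-((difluoromethyl)sulfanyl)benzyl on an amine nitrogen). Among the compounds with values here, no measured step covers this exchange; the only comparison available, from compound 1 to compound 2, moved the value by no more than the usual scatter. Compound 3 is therefore expected to stay near the same region, with an estimated step of a number no higher from compound 2 to compound 3 (the limit leaves the size open). The estimate for compound 3 in this assay is 5000 nM, within 1500 nM to 15000 nM.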

Compound 3, half-maximal cytotoxic concentration: 9800 nM
Beside the measured number, compound 3's estimate is 2.0-fold (0.29 log units) below it, and the stated range covers the measured number.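

In this assay, 1-(3-chloro-4-(dimethylamino)phenyl)ethyl in place of 4-hydroxybenzyl on an amine nitrogen gives a 2.0-fold higher number from compound 1 to compound 3 (0.30 log units; within the scatter), so compound 1 and compound 3 cannot be told apart. Within the data shown here, this is the first readable comparison at this position, and it shows that two quite different groups on the amine nitrogen can give values within the usual scatter of each other. The step that links compound 2 to compound 3 cannot be read, because the only value for compound 2 is a limit: the limit of > 5000 nM in this assay, at which 1 of the 3 values shown sits.

Compound 3 brings in the chlorine and the dimethylamino group together, so the compounds shown cannot separate what each contributes. Going by these compounds, how a benzyl ring carrying a carboxylic acid would behave at this position also remains open.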